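The compounds below may be only part of what the source reports. "The series", "measured", "known", "first", "only" and "open" are said of these compounds alone.

Measured in a functional assay on MDA-MB-435 cells (Homo sapiens) for inhibition, read by sulforhodamine B assay, with a stated time of 48 h; a higher number here means that more compound is tolerated, a lower number that less compound is tolerated:
- Compound 1 `COc1cc(-c2cc(/C=C/C(=O)c3ccc(N)cc3)[nH]n2)cc(OC)c1OC`: 6200 nM
- Compound 2 `COc1cc(-c2cc(/C=C/C(=O)c3ccc(Cl)c(Cl)c3)[nH]n2)cc(OC)c1OC`: > 100000 nM, a limit
- Compound 3 `COc1ccc(C(=O)/C=C/c2cc(-c3cc(OC)c(OC)c(OC)c3)n[nH]2)cc1`: > 100000 nM, a limit

Compound 2 stands at the limit of > 100000 nM in this assay, at which 2 of the 3 values shown sit. It therefore offers a limit and no number as the starting point.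

Compound 4 `COc1cc(-c2cc(/C=C/C(=O)c3ccc(F)c(F)c3)[nH]n2)cc(OC)c1OC` departs from compound 2 in one place, where 3,4-difluorophenyl stands in place of 3,4-dichlorophenyl on a carbonyl carbon: 3,4-difluorophenyl in place of 3,4-dichlorophenyl on a carbonyl carbon.

For the measured compounds named here, no measured step makes this exchange directly. Going by the values given here, two steps bear on it indirectly, and both are large and beyond the scatter: an at least 16-fold higher number from compound 1 to compound 2 (1.20 log units; beyond the scatter), and an at least 16-fold higher number from compound 1 to compound 3 (1.20 log units; beyond the scatter). Each of them takes away the 4-aminophenyl group, and compound 4 lacks that group as well. Among the three measured compounds, only compound 1 gives a number. The remaining step, a step that the two limits leave unreadable from compound 2 to compound 3, adds nothing that can be read.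

Compound 4 is therefore expected to stay close to the limit, quite possibly reported only as a limit, with no change beyond the scatter. The expected step is an at least 1.4-fold lower number from compound 2 to compound 4 (0.15 log units; that floor lies within the scatter). For compound 4 the estimated value is 70000 nM, with an expected range from 15000 nM to 100000 nM.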

Compound 4, concentration lethal to 50% of the cells: > 100000 nM
Compound 4: a limit, no number; the forecaster's own chance of this, stated with the estimate: 65%; at least 1.4-fold (0.15 log units) between middle value and limit.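

In this assay compound 4 gives > 100000 nM, which is a limit and not a number. Against compound 1, the only compound here with a number, 3,4-difluorophenyl in place of 4-aminophenyl on the carbonyl carbon gives an at least 16-fold higher number from compound 1 to compound 4 (1.20 log units; beyond the scatter), so 3,4-difluorophenyl joins 3,4-dichlorophenyl and 4-methoxyphenyl as a third group at this place that lacks the amino group and leaves no number to read. The steps from compound 2 and from compound 3 to compound 4 cannot be read, so fluorine in place of chlorine on this ring brings no value into range, and the limit now holds most of the series: the limit of > 100000 nM in this assay, at which 3 of the 4 values shown sit.

As far as these compounds go, whether compounds 2, 3 and 4 differ from one another at all stays open, since none of the three gives a number in this assay. From the compounds shown here alone, it is also open whether the value of compound 1 depends on the amino group alone or would also appear with another group at this place, such as 4-(dimethylamino)phenyl, 4-hydroxyphenyl or 4-acetamidophenyl.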